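This account rests on a few compounds, and the source may have more. Where it says the series, first, only, none or still open, it means among the compounds named here.

Measured compounds:
compound 1 `Nc1cc(N)c2nc(-c3ccccc3)c(NCc3ccc(Cl)c(Cl)c3)nc2c1` with 2040 nM
compound 2 `CCOC(=O)[C@H](CCC(=O)O)NC(=O)c1ccc(Oc2nc3cc(N)cc(N)c3nc2-c2ccccc2)cc1` with 27500 nM

For the measured compounds named here, only two compounds have numbers in a functional assay on NCI-H522 cells (Homo sapiens) for inhibition, read by sulforhodamine B assay, with a stated time of 48 h; a higher number here means a weaker inhibitor of growth, a lower number a stronger inhibitor of growth. Compound 1 gives 2040 nM and compound 2 gives 27500 nM, so compound 1 holds the lower of the two numbers, and the gap between them lies beyond the usual scatter. The two structures differ in more than one place, so nothing more is drawn from that pair.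

Compound 3 `COc1ccc(CNc2nc3cc(N)cc(N)c3nc2-c2ccccc2)cc1` has not yet been measured in this assay. It differs from compound 1 in one place: 4-methoxyphenyl in place of 3,4-dichlorophenyl on a saturated chain carbon bound to a nitrogen on an aromatic ring. Going by the values given here, no measured pair shows what this kind of exchange does on the shared core, so the direction of the step cannot be read from the data. With that caveat, compound 3 is expected to give roughly 3500 nM, within a range from 1000 nM to 15000 nM. Among the compounds with values here, the step this implies, a 1.7-fold higher number from compound 1 to compound 3 (0.23 log units; within the scatter), is estimated to be a small weakening that may well stay within the scatter; a wide range is given because no comparable step has been measured.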

Compound 3, concentration for 50% growth inhibition: 10000 nM
Compound 3: middle estimate off by 2.9-fold (0.46 log units), on the low side; the range from low to high includes it.
By their numbers in this assay, from the lowest: compound 1; then compound 3; then compound 2.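

In this assay, for the compounds shown here, 4-methoxyphenyl in place of 3,4-dichlorophenyl on a saturated chain carbon bound to a nitrogen on an aromatic ring gives a 4.9-fold higher number from compound 1 to compound 3 (0.69 log units; beyond the scatter), the first step on the shared core that can be read. It shows that this position is not indifferent to the group it carries: the two groups have the same count of heavy atoms and the same ring, yet the exchange moves the number beyond the scatter, towards weaker inhibition of growth. The data shown offer no explanation for this step.

Going by these compounds alone, the single exchange removes both chlorines and adds the methoxy group at once, so it remains open how much of the step belongs to each change, and a plain benzyl group at this place would help to separate the two. As far as these compounds go, it is also open how groups of a different kind, such as an amine or a carboxylic acid on the benzyl ring, would behave at this position on the shared core.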